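Notes on compound 3, a 4-methoxyphenoxy analogue

A few compounds are considered here, and "the series" means these few. Any claim that something is new, unique, unknown or untested is made for them only; others in the source may bear on it.

Compound 1 `CCc1ccccc1N(Cc1nnc(Cc2ccc(Cl)cc2)o1)S(=O)(=O)c1ccc(C)cc1` is the reference point. Within the data shown here, in a functional assay on CHO cells for antagonist activity at prostaglandin E2 receptor EP1 subtype (Homo sapiens), read by FLIPR and calcium flux (a higher number here means a weaker inhibitor, a lower number a stronger inhibitor), compound 1 gives 316 nM, the lowest of the two numbers measured so far. Among the measured compounds shown here, compound 2 `Cc1ccc(S(=O)(=O)N(Cc2nnc(Cc3cccc(Cl)c3)o2)c2cccc(Cl)c2C)cc1` is the only other measured member; in this assay compound 2 gives 2000 nM, a higher number than that of compound 1 by a margin beyond the scatter. The two differ in several places, so no single change can be read off between them.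

Compound 3 `CCc1ccccc1N(Cc1nnc(Oc2ccc(OC)cc2)o1)S(=O)(=O)c1ccc(C)cc1` has not yet been measured. It differs from compound 1 in one place: 4-methoxyphenoxy in place of 4-chlorobenzyl on an aromatic carbon. For the measured compounds named here, no measured pair follows this change, so its size is unknown. The swap is a sizeable one, and a step toward a higher number in this assay is expected, though a result within the scatter cannot be ruled out. Compound 3 is estimated at 800 nM, with a range from 200 nM to 4000 nM. The expected step is a 2.5-fold higher number from compound 1 to compound 3 (0.40 log units; beyond the scatter).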

Compound 3, inhibition constant: 100 nM
For compound 3 the middle estimate is 8.0-fold (0.90 log units) above the measured one; the measured number lies below the stated range.
By their numbers in this assay, from the lowest: compound 3; then compound 1; then compound 2.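

Among these compounds, replacing 4-chlorobenzyl with 4-methoxyphenoxy on this aromatic carbon gives a 3.2-fold lower number from compound 1 to compound 3 (0.50 log units; beyond the scatter) in this assay, the first single-place change that can be read. The position is therefore not tied to 4-chlorobenzyl: the entering group counts two hydrogen-bond acceptors where the leaving group counts none, and the number still falls. No measurement on hand bears on why the number falls.

The swap alters the link to the six-membered ring and the group carried on that ring at once, so the compounds shown do not separate the two; 4-chlorophenoxy or 4-methoxybenzyl at this carbon would divide the step between them. Going by these compounds, whether a much smaller group on this carbon, such as an amine or a methyl, keeps the number this low also remains open.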